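The source may hold more compounds than are shown below. What is called first, only, known or untested is meant among the compounds shown, and "the series" means these compounds.

Compounds measured so far:
- compound 1 `Fc1ccc(C2CC(c3ccc(Cl)s3)=NN2c2nc(-c3ccccc3)cs2)cc1`: > 500 ug/mL
- compound 2 `Fc1ccc(C2CC(c3ccc(Cl)s3)=NN2c2nc(-c3ccc(Br)cc3)cs2)cc1`: > 500 ug/mL
- compound 3 `Cc1ccc(C2=NN(c3nc(-c4ccc(F)cc4)cs3)C(c3ccc(F)cc3)C2)s1`: > 500 ug/mL

In an ADME assay on NIH3T3 cells (Mus musculus) for cytotoxicity, read by XTT assay, with a stated time of 24 h (on this read-out higher numbers stand for weaker inhibition and lower numbers for stronger inhibition), compound 3 returns only a limit, > 500 ug/mL, and not a number. The same holds for compound 1, whose result in this assay is likewise the limit > 500 ug/mL. Compound 2 too reaches only the limit > 500 ug/mL in this assay. Going by the values given here, all three sit at the limit of > 500 ug/mL in this assay, at which 3 of the 3 values shown sit, so no compound among them can be told apart from another on this read-out.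

Compound 4 `Cc1ccc(C2=NN(c3nc(-c4ccc(S(C)(=O)=O)cc4)cs3)C(c3ccc(F)cc3)C2)s1` is yet to be measured. It differs from compound 3 by methylsulfonyl in place of fluoro on an aromatic carbon. Among the compounds with values here, the only comparable step among the measured compounds, bromo in place of hydrogen on an aromatic carbon, is a step that the two limits leave unreadable from compound 1 to compound 2, which two limits leave unreadable and which therefore carries no information on size or direction. Within the data shown here, no measured step bears directly on methylsulfonyl in place of fluoro.

With every measured value resting at the limit, the step of a number no higher from compound 3 to compound 4 (the limit leaves the size open) is expected to be none beyond the scatter, and compound 4 is expected to sit at the limit as well. The estimate for compound 4 in this assay is 500 ug/mL, between 250 ug/mL and 1000 ug/mL.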

Compound 4, half-maximal inhibitory concentration: 374 ug/mL
Compound 4: the middle estimate sits 1.3-fold (0.13 log units) above what was measured, within the range that was stated.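

At this position, on an aromatic carbon para to a large group, methylsulfonyl in place of fluoro yields the first number rather than a limit in this assay, with compound 4 giving 374 ug/mL. On these data alone, the change from 4-fluorophenyl to 4-(methylsulfonyl)phenyl is an at least 1.3-fold lower number from compound 3 to compound 4 (0.12 log units; that floor lies within the scatter), so the smallest step the data allow is not a change beyond the scatter, and its true size remains unknown. Even so, the result shows that this position can accommodate a larger group while still giving a readable value in this assay, and compound 4 alone among the four is not held at the shared limit: the limit of > 500 ug/mL in this assay, at which 3 of the 4 values shown sit.

The steps that join two limits cannot be read, so the compounds shown say nothing about how bromo in place of hydrogen acts on this read-out. They also leave open whether an amine, a carboxylic acid or a longer chain at the same position would give a number in this assay, and whether methylsulfonyl would give a reading against the other compounds' cores.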